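Benzoyloxy replaces benzoyl on the ring nitrogen

The source may hold more compounds than are shown below. What is called first, only, known or untested is meant among the compounds shown, and "the series" means these compounds.

Measured so far:
- compound 1, `Cc1ccc(-c2nc(NO)c3cc(Cl)ccc3n2)cc1`: 6.81 ug/mL
- compound 2, `Cc1ccc(-c2nc(NC(=O)c3ccccc3)c3cc(Cl)ccc3n2)cc1`: 16.1 ug/mL

In a functional assay on MCF7 cells (Homo sapiens) for antiproliferative activity, read by MTT assay, with a stated time of 48 h (on this read-out higher numbers stand for weaker inhibition and lower numbers for stronger inhibition), compound 2 stands highest of the two numbers, with compound 1 nearest at a 2.4-fold higher number from compound 1 to compound 2 (0.37 log units; beyond the scatter), a modest step beyond the scatter. Compound 3, `Cc1ccc(-c2nc(NOC(=O)c3ccccc3)c3cc(Cl)ccc3n2)cc1`, differs from compound 2 by benzoyloxy in place of benzoyl on a nitrogen on an aromatic ring. Going by the values given here, only the step from compound 1 to compound 2 bears on this change, and it was modest. Compound 3 keeps the oxygen on the nitrogen that compound 1 carries, so the number for compound 3 is expected to move back somewhat toward compound 1, a modest lowering of a 1.8-fold lower number from compound 2 to compound 3 (0.25 log units; within the scatter). Compound 3 is estimated at 9 ug/mL, within 4 ug/mL to 22 ug/mL.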

Compound 3, half-maximal inhibitory concentration: 5.59 ug/mL
Compound 3: middle estimate off by 1.6-fold (0.21 log units), on the high side; the range from low to high includes it.
By their numbers in this assay, from the lowest: compounds 3 and 1 (each within the scatter of the next); then compound 2.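

In this assay, benzoyloxy in place of benzoyl on this nitrogen gives a 2.9-fold lower number from compound 2 to compound 3 (0.46 log units; beyond the scatter), so the same benzoyl ring is tolerated once an oxygen carries it, and the higher number belongs to compound 2 alone among these three. Benzoyl in place of hydrogen on the oxygen gives a 1.2-fold lower number from compound 1 to compound 3 (0.09 log units; within the scatter), so this large addition leaves the read-out unmoved. Nothing available explains either step. On these data alone, whether a smaller acetyl or a methyl on that oxygen would read the same remains open. So does how a plain amine at this place would compare.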